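This account rests on a few compounds, and the source may have more. Where it says the series, first, only, none or still open, it means among the compounds named here.

Measured so far in a functional assay on MCF7 cells (Homo sapiens) for inhibition, read by MTT assay, with a stated time of 72 h, tested at 10 uM; a higher number here means more inhibition at the concentration tested (going by the name of the read-out), a lower number less inhibition:
- compound 1 `CCOC(=O)C1=C(Nc2ccccc2)S/C(=C\c2ccc(O)c(O)c2)C1=O` gives 38.1%
- compound 2 `CCOC(=O)C1=C(Nc2ccccc2)S/C(=C\c2ccc(OC)cc2)C1=O` gives 14.7%
- compound 3 `CCOC(=O)C1=C(Nc2ccccc2)S/C(=C\c2ccc(Br)c(O)c2)C1=O` gives 16.4%

Compound 3 stands second highest of these three numbers. Its nearest neighbour is compound 2, with a number 1.7 percentage points higher from compound 2 to compound 3 (within the scatter), a step within the scatter. Its furthest is compound 1: the step of a number 21.7 percentage points lower from compound 1 to compound 3 (beyond the scatter), bromo in place of hydroxy on an aromatic carbon, lies beyond the scatter. The other step beyond the scatter is a number 23.4 percentage points lower from compound 1 to compound 2 (beyond the scatter), an exchange of the whole aryl group.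

Compound 4 `CCOC(=O)C1=C(Nc2ccccc2)S/C(=C\c2ccc(C(=O)O)cc2)C1=O` is the next member of the series. Its change from compound 3 is 4-carboxyphenyl in place of 4-bromo-3-hydroxyphenyl on a double-bonded chain carbon bound to a double-bonded ring carbon. Going by the values given here, no measured step introduces a carboxy on the aryl group, so nothing bears on it directly. Indirectly, the two aryl exchanges bear on it: a number 23.4 percentage points lower from compound 1 to compound 2 (beyond the scatter) and a number 1.7 percentage points higher from compound 2 to compound 3 (within the scatter). The two aryl groups without the 3,4-dihydroxy arrangement give values close to one another, and the carboxyphenyl compound is expected to stay in that neighbourhood rather than return toward compound 1.

Compound 4 is therefore expected to give 17% in this assay, within 4% to 34%. The expected step from compound 3 to compound 4 is a number 0.6 percentage points higher from compound 3 to compound 4 (within the scatter), not beyond the scatter.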

Compound 4, a percentage reported as inhibition, at one concentration (the size of the read-out at that concentration, not a potency): < 10%
Compound 4: only a limit was reported; the forecaster's own chance of this, stated with the estimate: 0%; middle value at least 7 percentage points from the limit.
By their numbers in this assay, from the lowest: compounds 2 and 3 (each within the scatter of the next); then compound 1. At a limit, below all of these: compound 4.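

Compound 4 in this assay gives < 10%, which is a limit of the assay and not a number: the limit of < 10% in this assay, at which 1 of the 4 values shown sits.

Set against the 3,4-dihydroxyphenyl group at this place, the 4-carboxyphenyl group shows a number at least 28.1 percentage points lower from compound 1 to compound 4 (beyond the scatter), so compounds 2, 3 and 4 now make three aryl groups that all fall short of compound 1, and a carboxy on the aryl group does not restore that level. Against the other two aryl groups only floors can be read, a number at least 6.4 percentage points lower from compound 3 to compound 4 (that floor lies within the scatter) and a number at least 4.7 percentage points lower from compound 2 to compound 4 (that floor lies within the scatter), which leaves the place of compound 4 relative to compounds 2 and 3 unsettled.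

Still open, as far as these compounds go, is whether a single hydroxy on the aryl group, or an amine or a methyl ester in place of the carboxy, would come closer to compound 1 in this assay. From the compounds shown here alone, all four compounds also carry the same ethyl ester and phenylamino group on the shared core, so whether the aryl groups keep these relations with a longer ester chain stays open as well.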